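The compounds below may be only part of what the source reports. "The series", "measured", "known", "first", "only" and "open" are said of these compounds alone.

Compounds measured so far:
- compound 1, `COc1ccc(C(=O)/C=C/c2nc3ccccc3cc2-c2ccc(OC)cc2)cc1`, 8500 nM
- compound 2, `COc1ccc(-c2cc3ccccc3nc2/C=C/C(=O)c2ccc(OC)c(OC)c2)cc1`, 8860 nM
- compound 3, `COc1ccc(-c2cc3ccccc3nc2/C=C/C(=O)c2ccsc2)cc1`, 8210 nM

In a functional assay on A549 cells (Homo sapiens) for antiproliferative activity, read by XTT assay, with a stated time of 72 h (a lower number here means a stronger inhibitor, a higher number a weaker inhibitor), compound 3 sits together with compounds 1 and 2: the step of a 1.0-fold lower number from compound 1 to compound 3 (0.02 log units; within the scatter) and the step of a 1.1-fold lower number from compound 2 to compound 3 (0.03 log units; within the scatter) are both within the scatter, so no one of the three can be set apart from the others on these numbers. The step from compound 1 to compound 2, a 1.0-fold higher number from compound 1 to compound 2 (0.02 log units; within the scatter), is within the scatter as well.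

Compound 4, `COc1ccc(-c2cc3ccccc3nc2/C=C/C(=O)c2ccc[nH]2)cc1`, differs from compound 3 in one place: 1H-pyrrol-2-yl in place of thiophen-3-yl on a carbonyl carbon. Among the compounds with values here, the steps that bear on this change are those that also swap the group on the carbonyl carbon, from compound 1 to compound 3 and from compound 2 to compound 3. Both were within the scatter, although neither of them brought in a hydrogen-bond donor in place of an acceptor, as this change does. Within the data shown here, no measured step speaks for a shift in either direction, so the step from compound 3 to compound 4 in this assay is expected to stay within the scatter, a 1.0-fold lower number from compound 3 to compound 4 (0.00 log units; within the scatter).

Compound 4 is therefore estimated at 8200 nM in this assay, with a range from 4000 nM to 17000 nM.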

Compound 4, half-maximal inhibitory concentration: > 10000 nM
Compound 4 gave a limit, no number (the forecaster's own chance of this, stated with the estimate: 5%); at least 1.2-fold (0.08 log units) between middle value and limit.
By their numbers in this assay, from the lowest: compounds 3, 1 and 2 (each within the scatter of the next). At a limit, above all of these: compound 4.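

In this assay compound 4 gives > 10000 nM, which is a limit of the assay and not a number. The steps of an at least 1.2-fold higher number from compound 3 to compound 4 (0.08 log units; that floor lies within the scatter) and an at least 1.1-fold higher number from compound 2 to compound 4 (0.05 log units; that floor lies within the scatter) and an at least 1.1-fold higher number from compound 1 to compound 4 (0.07 log units; that floor lies within the scatter) have floors that all lie within the scatter, so 1H-pyrrol-2-yl on the carbonyl carbon cannot yet be set apart from thiophen-3-yl, 3,4-dimethoxyphenyl or 4-methoxyphenyl, although the true value of compound 4 may lie well beyond these floors. Within the data shown here, what is new is that this position now carries a group with a hydrogen-bond donor, and that compound 4 is the only compound here without a measured number: the limit of > 10000 nM in this assay, at which 1 of the 4 values shown sits.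

The compounds shown leave open how far compound 4 really stands from the other three, and whether the result follows the hydrogen on the ring nitrogen or the five-membered ring as a whole. A 1-methyl-1H-pyrrol-2-yl group or a thiophen-2-yl group on the same carbonyl carbon would help to separate these two readings.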